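The source may report more compounds than this note shows. Statements on the series, on what has been measured and on what is new or still open speak of the compounds shown alone.

Compound 1 `O=C(Nc1nc2ccc(Cl)cc2s1)c1cc(-c2ccc(F)cc2)n2nc(-c3ccccc3)cc2n1`: 13800 nM
Compound 2 `COc1cc(-c2cc(C(=O)Nc3nc4ccc(Cl)cc4s3)nc3cc(-c4ccccc4)nn23)cc(OC)c1OC`: 41700 nM
Compound 3 `O=C(Nc1nc2ccc(F)cc2s1)c1cc(-c2ccc(F)cc2)n2nc(-c3ccccc3)cc2n1`: 35500 nM

All three have been run in a functional assay on ACHN cells (Homo sapiens) for cytotoxicity, read by MTT assay, with a stated time of 48 h; a lower number here means a stronger inhibitor, a higher number a weaker inhibitor. Compound 3 gives the second highest of the three numbers; compound 2 sits within the scatter of it, while compound 1 lies beyond the scatter at the lower side, as a 2.6-fold higher number from compound 1 to compound 3 (0.41 log units; beyond the scatter) shows. Compound 4 `COc1ccc(-c2cc(C(=O)Nc3nc4ccc(F)cc4s3)nc3cc(-c4ccccc4)nn23)cc1OC` has not yet been measured. It differs from compound 3 in one place: 3,4-dimethoxyphenyl in place of 4-fluorophenyl on an aromatic carbon.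

Going by the values given here, one measured step bears on this change. In a 3.0-fold higher number from compound 1 to compound 2 (0.48 log units; beyond the scatter) a 3,4,5-trimethoxyphenyl took the place of the 4-fluorophenyl on the chloro analogue, and the number rose by a modest amount beyond the scatter. The change to compound 4 brings in 3,4-dimethoxyphenyl rather than 3,4,5-trimethoxyphenyl at the same place, so a rise of comparable or somewhat smaller size is the natural expectation; nothing among the three measured compounds points to a fall. The step in this assay is therefore expected to be a modest rise, a 2.1-fold higher number from compound 3 to compound 4 (0.32 log units; beyond the scatter). Compound 4 is estimated at 75000 nM, with a range of 30000 nM to 180000 nM.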

Compound 4, half-maximal inhibitory concentration: 8120 nM
The estimate for compound 4 lay 9.2-fold (0.97 log units) above the measured number; measured number outside the range, below it.
By their numbers in this assay, from the lowest: compounds 4 and 1 (each within the scatter of the next); then compounds 3 and 2 (each within the scatter of the next).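

Working notes: in this assay the exchange of 4-fluorophenyl for 3,4-dimethoxyphenyl on the fluoro compound gives a 4.4-fold lower number from compound 3 to compound 4 (0.64 log units; beyond the scatter) and so shows that this aromatic carbon, next to the ring nitrogen, can carry a replacement that lowers the number as well as one that raises it. The only earlier change at this place (a 3.0-fold higher number from compound 1 to compound 2 (0.48 log units; beyond the scatter)) brought in 3,4,5-trimethoxyphenyl on the chloro compound and ran the opposite way, so the methoxy-bearing phenyl groups shown do not share one direction across the two halogen settings. No measurement shown here explains this reversal.

The compounds shown cannot separate the contribution of the extra methoxy group from that of the chloro or fluoro substituent, and that question needs both phenyl groups compared with the halogen held fixed. Also open, as far as these compounds go, is how this place responds to a single methoxy group, a hydroxyphenyl, a pyridyl ring or a phenyl bearing an amine such as morpholine.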